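The source may hold more compounds than are shown below. What is called first, only, known or untested is meant among the compounds shown, and "the series" means these compounds.

Measured in an ADME assay on microsomes from liver (Homo sapiens) for metabolic stability, using NADPH, with a stated time of 40 min, tested at 2 uM; on this read-out higher numbers stand for a longer-lived compound and lower numbers for a shorter-lived compound:

- Compound 1 `Cc1cccc2c(-c3ccc4ccc(F)cc4n3)c[nH]c12`: 0.883 h
- Compound 2 `Fc1cc(Cl)c2[nH]cc(-c3ccc4ccccc4n3)c2c1`: 0.383 h
- Compound 3 `Cc1cccc2c(-c3ccc4c(O)cccc4n3)c[nH]c12`: 0.283 h

Compound 3 at 0.283 h cannot be told apart from compound 2 at 0.383 h, as the two lie within the usual scatter of repeat measurements. Compound 1 at 0.883 h lies higher than compound 3, beyond that scatter.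

Compound 4 `CNC(=O)c1cccc2nc(-c3c[nH]c4c(C)cccc34)ccc12` has methylcarbamoyl in place of hydroxy on an aromatic carbon of compound 3 (methylcarbamoyl in place of hydroxy on an aromatic carbon). Among the compounds with values here, no two measured compounds differ in only one place, so nothing here shows the effect of this change directly, and the expectation is a small rise that stays within the scatter. The expected step is a 1.6-fold higher number from compound 3 to compound 4 (0.20 log units; within the scatter). For compound 4 the estimated half-life is 0.45 h, with an expected range from 0.18 h to 1.1 h.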

Compound 4, half-life: 0.983 h
The estimate for compound 4 lay 2.2-fold (0.34 log units) below the measured number, and the stated range covers the measured number.
By their numbers in this assay, from the lowest: compounds 3 and 2 (each within the scatter of the next); then compounds 1 and 4 (each within the scatter of the next).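

Replacing hydroxy with methylcarbamoyl on this aromatic carbon gives a 3.5-fold higher number from compound 3 to compound 4 (0.54 log units; beyond the scatter) in this assay. Within the data shown here, this is the first single-place comparison, and it shows that the group at this position can shift the half-life beyond the usual scatter. No measurement here explains the rise.

Going by these compounds, only these two groups can be compared at this carbon, so it remains open whether the rise comes from losing hydroxy or from adding methylcarbamoyl. A methoxy group, an amine or a carboxylic acid at the same carbon could help separate those two readings.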